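The compounds below may be only part of what the source reports. "The series", "measured", "known", "first", "only" and "open" are said of these compounds alone.

Measured so far:
- compound 1, `O=c1c(-c2ccc(O)cc2)coc2cc(OCCCCCCCCCO)ccc12`: > 9000 nM
- compound 2, `O=C(O)CCCCCOc1ccc2c(=O)cc(-c3ccc(O)cc3)oc2c1`: 7000 nM

Compound 1 is the reference point of the series. In an assay (Cricetulus griseus) for inhibition of Monoamine oxidase (Homo sapiens) (a higher number here means a weaker inhibitor, a lower number a stronger inhibitor), compound 1 gives > 9000 nM, which is a limit of the assay and not a number. It therefore sits at the limit of > 9000 nM in this assay, at which 1 of the 2 values shown sits, and its exact standing cannot be placed more closely than that. Compound 2 differs from compound 1 in the core and in the chain; in this assay compound 2 gives 7000 nM, a number rather than a limit, and a weak one.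

The next compound, compound 3, `C=CCCCCOc1ccc2c(=O)c(-c3ccc(O)cc3)coc2c1`, keeps the core of compound 1 and shortens the chain: vinyl in place of 5-hydroxypentyl on a saturated chain carbon, four bonds along the chain from an oxygen on an aromatic ring.

For the measured compounds named here, no measured step of this kind exists in the set, so the size of the change is not anchored. The chain grows shorter and loses its terminal hydroxyl; nothing measured shows what that does here. The step from compound 1 to compound 3 is expected to be small, without a direction that clears the scatter, as an at least 1.1-fold lower number from compound 1 to compound 3 (0.05 log units; that floor lies within the scatter). Compound 3 is thus estimated at 8000 nM in this assay, within 2500 nM to 25000 nM, with a fair chance that it again returns only a limit.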

Compound 3, half-maximal inhibitory concentration: 5000 nM
Compound 3: middle estimate off by 1.6-fold (0.20 log units), on the high side; the range from low to high includes it.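

On the core of compound 1, compound 3 gives 5000 nM in this assay, so this series now has a number rather than a limit on that core. The change from 5-hydroxypentyl to vinyl at this chain position reads as an at least 1.8-fold lower number from compound 1 to compound 3 (0.25 log units; that floor lies within the scatter) and is only a floor, so the shorter chain without its terminal hydroxyl shows no loss of inhibition, but no clear gain either. Compound 1 itself remains a limit of the assay: the limit of > 9000 nM in this assay, at which 1 of the 3 values shown sits.

Going by these compounds, the chain length and the terminal hydroxyl change together in this single step, so their separate contributions stay open. Also open, on these data alone, is what an amine at the end of the chain would do on this core, and whether any chain on it reaches a clearly stronger value.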